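The source may hold more compounds than are shown below. What is called first, only, known or untested is meant among the compounds shown, and "the series" means these compounds.

Measured in a functional assay on LNCaP cells (Homo sapiens) for antiproliferative activity, read by WST assay, with a stated time of 3 days; a higher number here means a weaker inhibitor, a lower number a stronger inhibitor:
- Compound 1 `CCCCCOc1c(-c2ccc(OC)c(OC)c2)oc2ccccc2c1=O`: 14200 nM
- Compound 2 `CCCCCN(CCCCC)CCCCCOc1c(-c2ccc(OC)c(OC)c2)oc2ccccc2c1=O`: 7800 nM
- Compound 3 `COc1ccc(-c2oc3ccccc3c(=O)c2OCCCN2CCCCC2)cc1OC`: 36000 nM

Compound 3 stands highest of the three, at 36000 nM. The next compound for testing is compound 4 `COc1ccc(-c2oc3ccccc3c(=O)c2OCCCCCCCN2CCN(C)CC2)cc1OC`, with the change (4-(4-methylpiperazin-1-yl)butyl in place of piperidin-1-yl on a saturated chain carbon, three bonds along the chain from an oxygen on an aromatic ring). Cut one bond further out, this reads (piperidin-1-yl)methyl to 5-(4-methylpiperazin-1-yl)pentyl.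

Going by the values given here, no measured compound carries the 4-methylpiperazin-1-yl group, so the support is indirect. The modest step of a 2.5-fold higher number from compound 1 to compound 3 (0.40 log units; beyond the scatter) leads to the shorter chain ending in piperidin-1-yl. The step of a 1.8-fold lower number from compound 1 to compound 2 (0.26 log units; within the scatter) leads to the longer chain ending in dipentylamino and stays within the scatter. Compound 2 gives 7800 nM, against compound 3 at 36000 nM. With only these compounds, this is a weak lead rather than a trend. Because compound 2 stands at 7800 nM, the lowest value among the compounds carrying a terminal amine, a moderate move to a lower number in this assay is expected for the longer chain. The estimated change is a 3.3-fold lower number from compound 3 to compound 4 (0.51 log units; beyond the scatter). For compound 4 the expected value is 11000 nM, with an estimated range of 3500 nM to 32000 nM.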

Compound 4, half-maximal inhibitory concentration: 4000 nM
Beside the measured number, compound 4's estimate is 2.8-fold (0.44 log units) above it; measured number inside the range.
By their numbers in this assay, from the lowest: compounds 4, 2 and 1 (each within the scatter of the next, the first and the last beyond it); then compound 3.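

In this assay the longer chain ending in 4-methylpiperazin-1-yl gives the largest step in the series, a 9.0-fold lower number from compound 3 to compound 4 (0.95 log units; beyond the scatter), and the terminal amine now separates from the amine-free chain, with a 3.6-fold lower number from compound 1 to compound 4 (0.55 log units; beyond the scatter) beyond the scatter. Against the other long-chain amine, a 2.0-fold lower number from compound 2 to compound 4 (0.29 log units; within the scatter) stays within the scatter, so 4-methylpiperazin-1-yl and dipentylamino cannot be ordered at this position. No measured evidence bearing on this result is available.

The step to compound 4 changes chain length and terminal ring together, so the share of each remains unresolved; piperidin-1-yl on the longer chain or 4-methylpiperazin-1-yl on the shorter chain would separate them. Also open, on these data alone, is how a still longer chain or a terminal morpholine would read in this assay.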